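Removing a Chloro in a Series Stuck at the Assay Limit

The source may report more compounds than this note shows. Statements on the series, on what has been measured and on what is new or still open speak of the compounds shown alone.

Compound 1, `COc1cc(-n2ncnc2-c2ccc(Cl)cc2)cc(OC)c1OC`, gives > 10000 nM in a functional assay on HeLa cells (Homo sapiens) for antiproliferative activity, read by MTT assay, with a stated time of 72 h (a lower number here means a stronger inhibitor, a higher number a weaker inhibitor), which is a limit of the assay and not a number.
Compound 2, `COc1cc(-n2ncnc2-c2ccc(Cl)c(Cl)c2)cc(OC)c1OC`, gives > 10000 nM in this assay, again a limit.
Compound 3, `COc1cc(-c2ncnn2-c2ccc(Cl)cc2)cc(OC)c1OC`, gives > 10000 nM in this assay, also a limit.

All three values sit at the limit of > 10000 nM in this assay, at which 3 of the 3 values shown sit. The change from compound 2 to compound 1, (hydrogen in place of chloro on an aromatic carbon), therefore gives a step whose size cannot be read: a step that the two limits leave unreadable from compound 2 to compound 1. The core of compound 3 differs from that of compound 2, but the difference between the two cores is not broken down here. Compound 4, `COc1cc(-c2ncnn2-c2ccccc2)cc(OC)c1OC`, has not yet been measured; it differs from compound 3 by hydrogen in place of chloro on an aromatic carbon. This is the same kind of change as that from compound 2 to compound 1, though the place differs: in compound 4 the hydrogen enters para to a large group, whereas in compound 1 it enters ortho to a chloro group and meta to a large group. Compound 3 gives only a limit, > 10000 nM. The earlier removal of a chloro left compound 1 at the same limit. On that basis compound 4 is expected to remain at the limit, with an estimated step that the limit leaves unreadable from compound 3 to compound 4. The estimate for compound 4 is 20000 nM, expected to lie between 6000 nM and 80000 nM.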

Compound 4, half-maximal inhibitory concentration: > 10000 nM
Compound 4 gave a limit, no number; the forecaster's own chance of this, stated with the estimate: 85%; the middle value does not contradict the limit.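

Compound 3 and compound 4 both sit at a limit of the assay, not at a number, so no step between them can be read: the limit of > 10000 nM in this assay, at which 4 of the 4 values shown sit.

The compounds shown leave open how strongly any of them acts in this assay, and whether removing a chloro changes that strength at all.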